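This account rests on a few compounds, and the source may have more. Where it says the series, first, only, none or still open, it means among the compounds named here.

Compound 1 `C=CC[C@H]1C[C@]2([C@@H](C)Cc3ccc(OC)cc3)OCOC2=CC1=O` and compound 2 `C=CC[C@H]1C[C@]2([C@@H](C)Cc3ccc(OC)c(F)c3)OCOC2=CC1=O` share one core and differ only by a fluoro group on the aromatic ring. For the measured compounds named here, in a functional assay on NCI-H460 cells (Homo sapiens) for antiproliferative activity, with a stated time of 72 h (a lower number here means a stronger inhibitor, a higher number a weaker inhibitor), compound 1 gives 90 nM, and in this assay compound 2 gives 90 nM; the step of no change at the digits printed from compound 1 to compound 2 (within the scatter) lies within the scatter, so compound 2 stands level with compound 1 on the numbers so far. Compound 3 `C=CC[C@H]1C[C@]2([C@@H](C)Cc3cc(F)c(OC)cc3F)OCOC2=CC1=O` carries a further change from compound 2: fluoro in place of hydrogen on an aromatic carbon. Going by the values given here, only one measured step bears on this kind of change, no change at the digits printed from compound 1 to compound 2 (within the scatter), which was also a fluoro in place of hydrogen on an aromatic carbon and left the result where it was. A second such exchange is therefore expected to move this assay little if at all, with an expected step of a 1.1-fold higher number from compound 2 to compound 3 (0.05 log units; within the scatter). Compound 3 is estimated at 100 nM, within a range from 45 nM to 220 nM.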

Compound 3, half-maximal inhibitory concentration: 59 nM
Beside the measured number, compound 3's estimate is 1.7-fold (0.23 log units) above it, within the range that was stated.
By their numbers in this assay, from the lowest: compounds 3, 1 and 2 (each within the scatter of the next).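

Placed on the aromatic ring ortho to a large group and para to a fluoro group, a second fluoro gives a 1.5-fold lower number from compound 2 to compound 3 (0.18 log units; within the scatter) in this assay. This shows that the ring of compound 2, which already carries one fluoro, can take another at this new position while the two compounds remain within the usual scatter of each other. Nothing shown here gives a reason for the size of this step.

The compounds shown leave open how this position would respond to a group of more than one atom, such as a methyl, an amine or a carboxylic acid. They also leave open how a fluoro at this position would read without the fluoro group para to it, since compound 3 carries both.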